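Working notes: dihydroxyphenyl step on the methoxy series

The source may hold more compounds than are shown below. What is called first, only, known or untested is meant among the compounds shown, and "the series" means these compounds.

- compound 1 `O=C(N/N=C/c1ccc(O)cc1O)Nc1cc2c(Nc3ccc(F)c(Cl)c3)ncnc2cc1O[C@H]1CCOC1`: 4530 nM
- compound 2 `COc1cc2ncnc(Nc3ccc(F)c(Cl)c3)c2cc1NC(=O)N/N=C/c1cccc(Cl)c1Cl`: 26100 nM
- compound 3 `COc1ccc(/C=N/NC(=O)Nc2cc3c(Nc4ccc(F)c(Cl)c4)ncnc3cc2OC)cc1`: 21300 nM
- compound 4 `COc1cc2ncnc(Nc3ccc(F)c(Cl)c3)c2cc1NC(=O)N/N=C/c1ccc(O)cc1O`: not yet measured

All values come from a functional assay on HepG2 cells (Homo sapiens) for cytotoxicity, read by MTT assay, with a stated time of 72 h; on this read-out higher numbers stand for weaker inhibition and lower numbers for stronger inhibition. In this assay compound 3 gives 21300 nM, within the scatter of compound 2. The lower number of compound 1 lies beyond the scatter of both.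

The next step leads to compound 4: 2,4-dihydroxyphenyl in place of 4-methoxyphenyl on a carbon with a double bond to nitrogen That is, 2,4-dihydroxyphenyl in place of 4-methoxyphenyl on a carbon with a double bond to nitrogen.

For the measured compounds named here, only one measured step falls at this place, a 1.2-fold lower number from compound 2 to compound 3 (0.09 log units; within the scatter), and it stays within the scatter. Taken alone, it argues for little movement. Against that, compound 1 at 4530 nM already carries the 2,4-dihydroxyphenyl, although its core also differs from that of compound 4. The data do not separate these two changes, so only part of that gap is carried over.

A modest move to a lower number is expected: a 2.1-fold lower number from compound 3 to compound 4 (0.33 log units; beyond the scatter). For compound 4 the estimated value is 10000 nM, with an expected range of 3500 nM to 24000 nM.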

Compound 4, half-maximal inhibitory concentration: 32100 nM
The estimate for compound 4 lay 3.2-fold (0.51 log units) below the measured number; the measured number lies above the stated range.
By their numbers in this assay, from the lowest: compound 1; then compounds 3, 2 and 4 (each within the scatter of the next).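

In this assay, the 2,4-dihydroxyphenyl on the carbon with a double bond to nitrogen gives no readable shift on the shared core, with a 1.5-fold higher number from compound 3 to compound 4 (0.18 log units; within the scatter) and a 1.2-fold higher number from compound 2 to compound 4 (0.09 log units; within the scatter), so the three groups tried at this place on that core stay within the scatter of one another. For the compounds shown here, the one step beyond the scatter is a 7.1-fold higher number from compound 1 to compound 4 (0.85 log units; beyond the scatter), where the only change is methyl in place of oxolan-3-yl on an oxygen on an aromatic ring, so this pair ties the gap to that place and not to the 2,4-dihydroxyphenyl. No supporting data on hand explain either result.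

As far as these compounds go, whether oxolan-3-yl has the same effect alongside 4-methoxyphenyl or 2,3-dichlorophenyl stays open, as compound 1 alone carries it. Also open, from the compounds shown here alone, is how an amine or a carboxylic acid on the carbon with a double bond to nitrogen, or a longer chain on the oxygen on an aromatic ring, would read.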